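This account rests on a few compounds, and the source may have more. Where it says the series, first, only, none or still open, it means among the compounds named here.

Working notes on the series. In a functional assay on MDA-MB-231 cells (Homo sapiens) for antiproliferative activity, read by XTT assay, with a stated time of 48 h (a higher number here means a weaker inhibitor, a lower number a stronger inhibitor), compound 1 `CC(=O)OC[C@H]1O[C@@H](n2cc(CN(c3ccccc3)S(=O)(=O)c3ccccc3)nn2)[C@H](OC(C)=O)[C@@H]1OC(C)=O` gives 100000 nM and compound 2 `CC(=O)OC[C@H]1O[C@@H](n2cc(CN(c3ccc(C)cc3)S(=O)(=O)c3ccccc3)nn2)[C@H](OC(C)=O)[C@@H]1OC(C)=O` gives 205000 nM. Compound 2 thus holds the highest of the two numbers, which makes it the weaker inhibitor of this pair. The next analogue is compound 3 `CC(=O)OC[C@H]1O[C@@H](n2cc(CN(c3ccc(Cl)cc3)S(=O)(=O)c3ccccc3)nn2)[C@H](OC(C)=O)[C@@H]1OC(C)=O`, which keeps the shared core and carries one change: chloro in place of methyl on an aromatic carbon. In words, this is chloro in place of methyl on an aromatic carbon, or 4-methylphenyl to 4-chlorophenyl. For the measured compounds named here, only one measured step bears on this change. Methyl in place of hydrogen on an aromatic carbon gave a 2.1-fold higher number from compound 1 to compound 2 (0.31 log units; beyond the scatter). Going by the values given here, no chloro compound has been measured in this assay, so the support is thin. With the methyl gone, a result close to compound 1 at 100000 nM is the working expectation, and a modest move to a lower number is therefore anticipated. The expected change is a 2.2-fold lower number from compound 2 to compound 3 (0.33 log units; beyond the scatter). For compound 3 the estimated value is 95000 nM, with an expected range of 40000 nM to 220000 nM.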

Compound 3, half-maximal inhibitory concentration: 250000 nM
For compound 3 the middle estimate is 2.6-fold (0.42 log units) below the measured one; the measured number lies above the stated range.
By their numbers in this assay, from the lowest: compound 1; then compounds 2 and 3 (each within the scatter of the next).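

In this assay, chloro in place of methyl, on the aromatic carbon para to a large group, gives a 1.2-fold higher number from compound 2 to compound 3 (0.09 log units; within the scatter) and so does not separate these two groups at this position. Set against the unsubstituted parent, chloro in place of hydrogen gives a 2.5-fold higher number from compound 1 to compound 3 (0.40 log units; beyond the scatter) in the same direction as a 2.1-fold higher number from compound 1 to compound 2 (0.31 log units; beyond the scatter) and beyond the scatter in both cases. Across these three compounds, the higher number therefore goes with having either group at this position rather than with which of the two is present, and compound 1 at 100000 nM remains the lowest value.

No measurement available here explains this behaviour at the position. Still open, on these data alone, is whether a group of another kind at this position, such as an amine, a methoxy or a carboxylic acid, would bring the number below that of compound 1, and whether replacing the acetyl groups on the shared core with hydroxyl groups would move it further than these steps do.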